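The source may report more compounds than this note shows. Statements on the series, on what has been measured and on what is new or still open speak of the compounds shown alone.

The values below come from a functional assay on SGC-7901 cells (Homo sapiens) for inhibition, read by MTT assay, with a stated time of 24 h (a higher number here means a weaker inhibitor, a lower number a stronger inhibitor), as measured so far
- Compound 1 `CC1(C)[C@H]2CC[C@]1(C)N(Cc1cn(-c3cccc(F)c3)nn1)C(=O)C2` (530 nM)
- Compound 2 `CC1(C)[C@H]2CC[C@]1(C)N(Cc1cn(-c3ccccc3F)nn1)C(=O)C2` (300 nM)
- Compound 3 `CC1(C)[C@H]2CC[C@]1(C)N(Cc1cn(-c3ccc(F)cc3)nn1)C(=O)C2` (500 nM)

Compound 3 (500 nM) cannot be separated from the other two, as a 1.1-fold lower number from compound 1 to compound 3 (0.03 log units; within the scatter) and a 1.7-fold higher number from compound 2 to compound 3 (0.22 log units; within the scatter) show. Compound 4 `CC1(C)[C@H]2CC[C@]1(C)N(Cc1cn(-c3ccccc3Cl)nn1)C(=O)C2` carries 2-chlorophenyl in place of 4-fluorophenyl on an aromatic nitrogen. For the measured compounds named here, no compound with a chlorophenyl group has been measured, so this swap has no direct precedent. The closest guide is compound 2, which holds 2-fluorophenyl on that nitrogen. Shifting the fluorine around the ring gave only small steps such as a 1.8-fold lower number from compound 1 to compound 2 (0.25 log units; within the scatter) and nothing beyond the scatter. A similarly small change is therefore expected in this assay (a 1.3-fold lower number from compound 3 to compound 4 (0.12 log units; within the scatter)), with no clear direction and no step beyond the scatter. The estimated value for compound 4 is 380 nM (expected range 170 nM to 850 nM).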

Compound 4, half-maximal inhibitory concentration: 220 nM
Compound 4: the middle estimate sits 1.7-fold (0.24 log units) above what was measured; the range from low to high includes it.
By their numbers in this assay, from the lowest: compounds 4, 2, 3 and 1 (each within the scatter of the next, the first and the last beyond it).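

Chloro brings the first steps beyond the scatter in this assay, both modest: 2-chlorophenyl in place of 4-fluorophenyl gives (a 2.3-fold lower number from compound 3 to compound 4 (0.36 log units; beyond the scatter)), and in place of 3-fluorophenyl it gives (a 2.4-fold lower number from compound 1 to compound 4 (0.38 log units; beyond the scatter)). The one-atom swap of chloro in place of fluoro on an aromatic carbon stays within the scatter (a 1.4-fold lower number from compound 2 to compound 4 (0.13 log units; within the scatter)), so compound 4 cannot be separated from compound 2, and only compound 4 stands clear of compound 1 and compound 3. No measurement here explains these differences.

The compounds shown leave open whether a chlorophenyl group depends on where its chlorine sits, a question that 4-chlorophenyl could address. They also leave open how a bromo group, a methoxy group or an amine would compare in place of the chloro.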